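Vinyl for phenoxy on the beta-lactam ring of compound 2

The source may hold more compounds than are shown below. What is called first, only, known or untested is meant among the compounds shown, and "the series" means these compounds.

Compound 2 `CCSc1ccc(C2C(Oc3ccccc3)C(=O)N2c2cc(OC)c(OC)c(OC)c2)cc1` gives 210 nM in a functional assay on MCF7 cells (Homo sapiens) for inhibition, read by resazurin assay, with a stated time of 72 h (on this read-out lower numbers stand for stronger inhibition and higher numbers for weaker inhibition), the highest number of the three measured; compound 1 `CCOc1ccc(C2C(Oc3ccccc3)C(=O)N2c2cc(OC)c(OC)c(OC)c2)cc1` gives 69 nM and compound 3 `COc1ccc(C2C(O)C(=O)N2c2cc(OC)c(OC)c(OC)c2)cc1O` gives 3 nM. The untested compound 4 `C=CC1C(=O)N(c2cc(OC)c(OC)c(OC)c2)C1c1ccc(SCC)cc1` differs from compound 2 in one place: vinyl in place of phenoxy on a saturated ring carbon. Among the measured compounds shown here, the only measured single step, a 3.0-fold higher number from compound 1 to compound 2 (0.48 log units; beyond the scatter), concerns a different position and the group on the aromatic carbon, so no measured step bears directly on this exchange; compound 3 carries a hydroxy at the corresponding ring carbon but also differs elsewhere. Without a direct precedent, compound 4 is expected to stay near compound 2, with a step of a 1.8-fold lower number from compound 2 to compound 4 (0.24 log units; within the scatter) of uncertain direction. The estimate for compound 4 is 120 nM, with a range from 30 nM to 500 nM.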

Compound 4, half-maximal inhibitory concentration: 181 nM
Compound 4: middle estimate off by 1.5-fold (0.18 log units), on the low side; the range from low to high includes it.
By their numbers in this assay, from the lowest: compound 3; then compound 1; then compounds 4 and 2 (each within the scatter of the next).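

In this assay, vinyl in place of phenoxy on this saturated ring carbon gives a 1.2-fold lower number from compound 2 to compound 4 (0.06 log units; within the scatter). Among the compounds shown here, with the 4-(ethylsulfanyl)phenyl group in place, this position therefore tolerates the loss of the phenoxy aromatic ring without a change beyond the scatter, which no earlier pair could show. Nothing shown explains this result. Compound 3 also differs elsewhere, so the effect of its hydroxy at this carbon remains unresolved. As far as these compounds go, whether an amine or a carboxylic acid here would shift the number also remains open.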